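Sulfur in Place of Oxygen in a Diaryl Linker

A few compounds are considered here, and "the series" means these few. Any claim that something is new, unique, unknown or untested is made for them only; others in the source may bear on it.

Measured compounds:
Compound 1 `O=C1NC(=O)C(Cc2ccc(Cc3ccccc3)cc2)S1` gives 9280 nM in a functional assay for agonist activity at Free fatty acid receptor 1 (Homo sapiens), read by FLIPR, in the presence of a further agent that is not named here; on this read-out higher numbers stand for an effect only at larger amounts of compound and lower numbers for an effect already at smaller amounts.
Compound 2 `O=C1NC(=O)C(Cc2ccc(Oc3ccccc3)cc2)S1` gives 307 nM in this assay.

For the measured compounds named here, compound 2 has the lowest of the two numbers; its only neighbour is compound 1, and the one measured step, a 30-fold lower number from compound 1 to compound 2 (1.48 log units; beyond the scatter), came with phenoxy in place of benzyl on an aromatic carbon. Compound 3 `O=C1NC(=O)C(Cc2ccc(Sc3ccccc3)cc2)S1` is not yet measured. It differs from compound 2 in one place: phenylsulfanyl in place of phenoxy on an aromatic carbon. Going by the values given here, the measured step bears on this only indirectly, since it shows that the atom linking the two rings can shift the number strongly, but no measured pair exchanges oxygen for sulfur. A smaller step than that one is therefore expected, estimated as a 1.6-fold higher number from compound 2 to compound 3 (0.21 log units; within the scatter), possibly within the scatter. Compound 3 is expected to give about 500 nM in this assay, with a range of 150 nM to 2000 nM.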

Compound 3, half-maximal effective concentration: 5060 nM
The estimate for compound 3 lay 10-fold (1.01 log units) below the measured number, outside the stated range (above it).
By their numbers in this assay, from the lowest: compound 2; then compounds 3 and 1 (each within the scatter of the next).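

Oxygen and sulfur are not interchangeable as the atom linking the two rings: phenylsulfanyl in place of phenoxy gives a 16-fold higher number from compound 2 to compound 3 (1.22 log units; beyond the scatter) in this assay. Phenylsulfanyl in place of benzyl gives only a 1.8-fold lower number from compound 1 to compound 3 (0.26 log units; within the scatter), so the sulfur and carbon links cannot be told apart here, while compound 2, the oxygen-linked member, has the lowest number of the three, with its steps to both others beyond the scatter. No measurement is available that would explain why the oxygen link stands apart.

Going by these compounds, it remains open whether a secondary amine or a carbonyl as the link would behave like the oxygen or like the sulfur and carbon. Also open, on these data alone, is whether a longer chain, such as a methyleneoxy link, would keep the low number of compound 2 307 nM.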